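Phenoxy in Place of Phenyl: What to Expect for Compound 4

This account rests on a few compounds, and the source may have more. Where it says the series, first, only, none or still open, it means among the compounds named here.

Compound 1 `CC(C)(C)OC(=O)N1C[C@H](O)C[C@H]1COCCCCCCCC/C=C/c1ccc(-c2ccccc2)cc1`: 37500 nM
Compound 2 `CC(C)(C)OC(=O)N1C[C@H](O)C[C@H]1COCCCCCCCCC/C=C/c1ccc(-c2ccccc2)cc1`: 36500 nM
Compound 3 `CC(C)(C)OC(=O)N1C[C@H](O)C[C@H]1COCCCCCCCC/C=C/c1ccc(Oc2ccccc2)cc1`: 41000 nM

These three compounds were tested in a functional assay on HeLa cells (Homo sapiens) for inhibition, with a stated time of 72 h; on this read-out higher numbers stand for weaker inhibition and lower numbers for stronger inhibition. Compound 1 and compound 2 share a core but differ in the length of the chain between the ring on the left and the double bond; the difference between the two cores is not broken down here, and their two values lie within the usual scatter of each other. Compound 3 arises from compound 1 by one change, (phenoxy in place of phenyl on an aromatic carbon), and the measured step was a 1.1-fold higher number from compound 1 to compound 3 (0.04 log units; within the scatter), so this change left the read-out essentially where it was.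

Compound 4 `CC(C)(C)OC(=O)N1C[C@H](O)C[C@H]1COCCCCCCCCC/C=C/c1ccc(Oc2ccccc2)cc1` is not yet measured. For the measured compounds named here, it arises from compound 2 by phenoxy in place of phenyl on an aromatic carbon, the same change at the same place as the one from compound 1 to compound 3. On that basis the expected step in this assay is a 1.1-fold higher number from compound 2 to compound 4 (0.04 log units; within the scatter), resting on the step of a 1.1-fold higher number from compound 1 to compound 3 (0.04 log units; within the scatter). The estimate for compound 4 is therefore 40000 nM, expected to fall between 24000 nM and 68000 nM.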

Compound 4, half-maximal inhibitory concentration: 45900 nM
Estimate against measurement, compound 4: 1.1-fold (0.06 log units) below; low and high end bracket the measured number.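

In this assay, putting phenoxy in place of phenyl gave a 1.3-fold higher number from compound 2 to compound 4 (0.10 log units; within the scatter), so on this second core the change again left the read-out essentially where it was. Set side by side, the two steps agree: the same change on two cores in this assay, a 1.1-fold higher number (0.04 log units; within the scatter) from compound 1 to compound 3 and a 1.3-fold higher number (0.10 log units; within the scatter) from compound 2 to compound 4, 1.2-fold (0.06 log units) apart, within the scatter of two such steps. This shows that the lack of a clear effect carried over between two cores that differ only in the length of their chain, but it rests on just two pairs and says nothing about a core that differs in some other way, nor does it show that the change has any real effect of its own, since both steps lie within the scatter.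

The compounds shown leave open whether a different group on that aromatic carbon, such as an amine or a carboxylic acid, would shift the read-out beyond the scatter. They also leave open whether the same swap would stay just as silent on a core with a much shorter chain.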